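Replacing Fluoro with Methanesulfonamido in a Substance-P Receptor Series

The source may report more compounds than this note shows. Statements on the series, on what has been measured and on what is new or still open speak of the compounds shown alone.

Measured in an assay on CHO cells for displacement of a labelled ligand from Substance-P receptor (Homo sapiens), in the presence of a further agent that is not named here; a lower number here means a stronger inhibitor, a higher number a weaker inhibitor:
Compound 1 `C[C@@H](O[C@H]1CN2C(=O)C=C(c3ccc(C#N)cc3)CC2[C@@H]1c1ccc(F)cc1)c1cc(C(F)(F)F)cc(C(F)(F)F)c1` gives 53 nM.
Compound 2 `C[C@@H](O[C@H]1CN2C(=O)C=C(c3ccc(F)cc3)CC2[C@@H]1c1ccc(F)cc1)c1cc(C(F)(F)F)cc(C(F)(F)F)c1` gives 100 nM.

Among the measured compounds shown here, compound 2 has the higher of the two numbers, but the only step between them, a 1.9-fold higher number from compound 1 to compound 2 (0.28 log units; within the scatter), lies within the scatter, so the two cannot be told apart. Compound 3 `C[C@@H](O[C@H]1CN2C(=O)C=C(c3ccc(NS(C)(=O)=O)cc3)CC2[C@@H]1c1ccc(F)cc1)c1cc(C(F)(F)F)cc(C(F)(F)F)c1` differs from compound 2 by methanesulfonamido in place of fluoro on an aromatic carbon. For the measured compounds named here, that one step is the only evidence at this position, and it showed no change beyond the scatter; no measured step introduces a group like methanesulfonamido. The expected step is a 1.5-fold higher number from compound 2 to compound 3 (0.18 log units; within the scatter), with wide uncertainty. Compound 3 is estimated at 150 nM, between 40 nM and 600 nM.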

Compound 3, half-maximal inhibitory concentration: 54 nM
For compound 3 the middle estimate is 2.8-fold (0.44 log units) above the measured one; the range from low to high includes it.
By their numbers in this assay, from the lowest: compounds 1, 3 and 2 (each within the scatter of the next).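

In this assay methanesulfonamido, which brings a hydrogen-bond donor and more heavy atoms than fluoro, gives a 1.9-fold lower number from compound 2 to compound 3 (0.27 log units; within the scatter) and, in place of cyano, a 1.0-fold higher number from compound 1 to compound 3 (0.01 log units; within the scatter). Both steps lie within the scatter, so fluoro, cyano and methanesulfonamido on this aromatic carbon cannot be told apart, even though the new group differs so much from the other two. Nothing measured here explains this result. From the compounds shown here alone, whether an amine or a carboxylic acid at this position would give a step beyond the scatter stays open, as does the effect of a longer chain in place of the methyl on the sulfonyl group.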